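Swapping Ethylpiperazine for Methylpiperidine on a Shared Core

A few compounds are considered here, and "the series" means these few. Any claim that something is new, unique, unknown or untested is made for them only; others in the source may bear on it.

Measured compounds:
compound 1, `CCN1CCC(c2ccc3c(c2)oc(=O)n3C(=O)NCCCCc2ccccc2)CC1`: 92 nM
compound 2, `CCN1CCN(c2ccc3c(c2)oc(=O)n3C(=O)NCCCCc2ccccc2)CC1`: 56 nM
compound 3, `CC(=O)N1CCc2oc(=O)n(C(=O)NCCCCc3ccccc3)c2C1`: 293 nM

Of the compounds shown here, three have been measured in an assay on HEK293 cells for inhibition of acid ceramidase (Homo sapiens), read by fluorescence, with stated times of 10 min and 3 h; on this read-out higher numbers stand for weaker inhibition and lower numbers for stronger inhibition. Compound 2 carries a 4-ethylpiperazin-1-yl group on its shared core and gives the lowest number of the three, with compound 1 next to it and compound 3, built on a different core, the furthest away. Going by the values given here, the one single-point step in the set runs a 1.6-fold lower number from compound 1 to compound 2 (0.22 log units; within the scatter), so the two aromatic-core compounds cannot be told apart on these numbers.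

Compound 4, `CN1CCC(c2ccc3c(c2)oc(=O)n3C(=O)NCCCCc2ccccc2)CC1`, is the next compound to be measured in this assay. Its difference from compound 2 is 1-methylpiperidin-4-yl in place of 4-ethylpiperazin-1-yl on an aromatic carbon. The measured step from compound 1 to compound 2 bears directly on the ring part of this change, since it replaced a 1-ethylpiperidin-4-yl group by the 4-ethylpiperazin-1-yl group and stayed within the scatter. Among the compounds with values here, no measured pair speaks to the shortening from an ethyl to a methyl on the ring nitrogen. Compound 4 is therefore expected to land close to compound 1, with the step of a 1.6-fold higher number from compound 2 to compound 4 (0.21 log units; within the scatter) expected to stay within the scatter. The estimate for compound 4 is 90 nM, in the range 40 nM to 200 nM.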

Compound 4, half-maximal inhibitory concentration: 129 nM
The estimate for compound 4 lay 1.4-fold (0.16 log units) below the measured number, and the stated range covers the measured number.
By their numbers in this assay, from the lowest: compounds 2, 1 and 4 (each within the scatter of the next, the first and the last beyond it); then compound 3.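

In this assay, going by these compounds alone, putting 1-methylpiperidin-4-yl in place of 4-ethylpiperazin-1-yl on this aromatic carbon gives a 2.3-fold higher number from compound 2 to compound 4 (0.36 log units; beyond the scatter) and this modest step is the first on the shared core to pass beyond the scatter. Within the data shown here, the shortening of the chain on the ring nitrogen, which no earlier pair addressed, now stands alone in a 1.4-fold higher number from compound 1 to compound 4 (0.15 log units; within the scatter) and so, on these numbers, the ethyl and methyl forms of the piperidine cannot be told apart, just as the two ethyl-bearing rings could not be. No measurement at hand accounts for either step.

The compounds shown leave open how 4-methylpiperazin-1-yl would read on the same core, a comparison that would set the ring change against the chain change with the methyl group held fixed and would show whether the two small steps simply add up to the larger one. Also open, going by these compounds, is how the shared core would read with a hydrogen or a longer chain such as propyl on the ring nitrogen.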